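This account rests on a few compounds, and the source may have more. Where it says the series, first, only, none or still open, it means among the compounds named here.

Three compounds sharing one core have numbers in a functional assay on M21 cells (Homo sapiens) for antiproliferative activity, read by sulforhodamine B assay, with a stated time of 48 h; a lower number here means a stronger inhibitor, a higher number a weaker inhibitor. Compound 1 (`Cc1cccc(NS(=O)(=O)c2ccc(N3CCNC3=O)cc2)c1`) gives 69 nM, compound 2 (`COc1ccc(NS(=O)(=O)c2ccc(N3CCNC3=O)cc2)cc1OC`) gives 340 nM, and compound 3 (`Cc1ccccc1NS(=O)(=O)c1ccc(N2CCNC2=O)cc1`) gives 150 nM. Compound 3 therefore holds the middle place, with the second highest of the three numbers, and its gaps to both neighbours lie beyond the scatter.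

The next compound is compound 4 (`COc1cccc(NS(=O)(=O)c2ccc(N3CCNC3=O)cc2)c1`), in which 3-methoxyphenyl stands in place of 2-methylphenyl on a sulfonamide nitrogen: 3-methoxyphenyl in place of 2-methylphenyl on a sulfonamide nitrogen.

Going by the values given here, only one measured step bears on this change, namely a 2.2-fold higher number from compound 1 to compound 3 (0.34 log units; beyond the scatter). That step is modest, and it shows the 2-methylphenyl compound with the higher number. Removing that group might thus lower the number a little, as the value of compound 1 at 69 nM suggests. The methoxy-bearing compound 2 argues for caution, since it has the highest number at 340 nM. Among the compounds with values here, no measured step isolates 3-methoxyphenyl itself, so a small shift towards a lower number in this assay is expected, possibly none beyond the scatter.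

The estimated step is a 1.4-fold lower number from compound 3 to compound 4 (0.13 log units; within the scatter). For compound 4 the expected value is 110 nM, with an estimated range from 45 nM to 270 nM.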

Compound 4, half-maximal inhibitory concentration: 65 nM
Compound 4: the middle estimate sits 1.7-fold (0.23 log units) above what was measured; low and high end bracket the measured number.
By their numbers in this assay, from the lowest: compounds 4 and 1 (each within the scatter of the next); then compound 3; then compound 2.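

In this assay, 3-methoxyphenyl on the sulfonamide nitrogen does better than 2-methylphenyl, with a 2.3-fold lower number from compound 3 to compound 4 (0.36 log units; beyond the scatter), while methoxy in place of methyl on an aromatic carbon gives a 1.1-fold lower number from compound 1 to compound 4 (0.03 log units; within the scatter), so the data do not separate the methoxy and methyl compounds 4 and 1. Going by these compounds alone, the high number of compound 2 therefore cannot be read as a penalty for any methoxy group on this ring, since hydrogen in place of methoxy on an aromatic carbon gives a 5.2-fold lower number from compound 2 to compound 4 (0.72 log units; beyond the scatter), which ties that number to the extra methoxy of compound 2 and not to the one it shares with compound 4. Nothing available explains why these changes move the number as they do.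

The compounds shown leave open how far this tolerance extends, for instance whether an ethoxy group, a chlorine atom or an amine in the place of that methoxy would keep the number near those of compounds 1 and 4. They also leave open whether a cyclohexyl group on the sulfonamide nitrogen could replace the aromatic ring altogether.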